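The source may hold more compounds than are shown below. What is called first, only, known or untested is meant among the compounds shown, and "the series" means these compounds.

Of the compounds shown here, three have been read in a functional assay on HeLa cells (Homo sapiens) for cytotoxicity, read by MTT assay (on this read-out lower numbers stand for stronger inhibition and higher numbers for weaker inhibition), so far. Compound 1 (`COC(=O)C[C@H]1C[C@H](O)[C@@H](C)[C@@H](c2ccc(C)cc2)N1`) is recorded as "not active" (no number reported) with no number reported. Compound 2 (`COC(=O)C[C@H]1C[C@H](O)[C@@H](C)[C@@H](c2ccc(C(C)C)cc2)N1`) gives 18200 nM and compound 3 (`COC(=O)C[C@H]1C[C@@H](O)[C@@H](C)[C@@H](c2ccc(OC)cc2)N1`) gives 11500 nM in the same read-out. These two values lie within the scatter of each other, so compound 3 stands level with compound 2.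

Compound 4 (`COC(=O)C[C@H]1C[C@H](O)[C@@H](C)[C@@H](c2ccc(OC)cc2)N1`) has not been measured. Its relation to compound 3 is the two compounds have the same atoms and bonds and differ only in configuration as drawn: 1 of 4 stereo elements differ; a stereocentre at a saturated ring carbon is drawn R in compound 3 and S in compound 4 (a stereocentre at a saturated ring carbon is drawn R in compound 3 and S in compound 4). For the measured compounds named here, no measured pair isolates a change of configuration, so the data offer no direct precedent. A modest step toward weaker inhibition in this assay is expected, close to the edge of the scatter (a 1.6-fold higher number from compound 3 to compound 4 (0.19 log units; within the scatter)). A report without a number, as for compound 1, also remains possible. For compound 4 the estimated value is 18000 nM (expected range 7500 nM to 45000 nM).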

Compound 4, half-maximal inhibitory concentration: 5300 nM
Beside the measured number, compound 4's estimate is 3.4-fold (0.53 log units) above it, outside the stated range (below it).
By their numbers in this assay, from the lowest: compound 4; then compounds 3 and 2 (each within the scatter of the next).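

In this assay the series now has its first pair that isolates configuration, with a 2.2-fold lower number from compound 3 to compound 4 (0.34 log units; beyond the scatter) and so showing that the configuration drawn at this saturated ring carbon alters the read-out. That step can be assigned to this single stereocentre alone because no other structural feature changes: the fact that compounds 3 and 4 differ only in the configuration as drawn. For the compounds shown here, with the configuration held, the swap of methoxy in place of isopropyl on an aromatic carbon gives a 3.4-fold lower number from compound 2 to compound 4 (0.54 log units; beyond the scatter) and adds a first step beyond the scatter for a change of aromatic substituent.

As far as these compounds go, whether inverting the same stereocentre shifts the number in the same direction with isopropyl in place of methoxy remains open. Also open, from the compounds shown here alone, is how an amine or a carboxylic acid at the aromatic position would read in this assay in either configuration.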